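From a Butyl Chain to a Chloro Group

This account rests on a few compounds, and the source may have more. Where it says the series, first, only, none or still open, it means among the compounds named here.

In a functional assay on HeLa cells (Homo sapiens) for inhibition (on this read-out higher numbers stand for weaker inhibition and lower numbers for stronger inhibition), compound 1 `O=C(O)CSC(CC(=O)c1ccccc1)C(=O)O` gives 15000 nM, compound 2 `CCc1ccc(C(=O)CC(SCC(=O)O)C(=O)O)cc1` gives 4790 nM and compound 3 `CCCCc1ccc(C(=O)CC(SCC(=O)O)C(=O)O)cc1` gives 1920 nM. Compound 3 thus holds the lowest of the three numbers, and its steps to both others lie beyond the scatter. The next structure is compound 4 `O=C(O)CSC(CC(=O)c1ccc(Cl)cc1)C(=O)O`, still unmeasured in this assay. The change is chloro in place of butyl on an aromatic carbon, para to a large group.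

Among the measured compounds shown here, three measured steps bear on this change, all of them modest. Ethyl in place of hydrogen gave a 3.1-fold lower number from compound 1 to compound 2 (0.50 log units; beyond the scatter), butyl in place of hydrogen gave a 7.8-fold lower number from compound 1 to compound 3 (0.89 log units; beyond the scatter), and the longer chain gave a further a 2.5-fold lower number from compound 2 to compound 3 (0.40 log units; beyond the scatter). Among these three compounds, the number falls as the chain grows, and none goes against that trend. For the measured compounds named here, no chloro compound has been measured, so these steps offer only indirect guidance. Losing the butyl group could give back part of a 7.8-fold lower number from compound 1 to compound 3 (0.89 log units; beyond the scatter), so compound 4 is expected to fall between the values of the other compounds, near compound 2 at 4790 nM. The expected change is a modest rise in the number, a 3.1-fold higher number from compound 3 to compound 4 (0.49 log units; beyond the scatter). For compound 4 the estimated value is 6000 nM, with an expected range from 2500 nM to 14000 nM.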

Compound 4, half-maximal inhibitory concentration: 17200 nM
For compound 4 the middle estimate is 2.9-fold (0.46 log units) below the measured one, outside the stated range (above it).
By their numbers in this assay, from the lowest: compound 3; then compound 2; then compounds 1 and 4 (each within the scatter of the next).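

In this assay, the aromatic carbon para to a large group proves sensitive to which group it carries: chloro in place of butyl gives a 9.0-fold higher number from compound 3 to compound 4 (0.95 log units; beyond the scatter) and chloro in place of ethyl gives a 3.6-fold higher number from compound 2 to compound 4 (0.56 log units; beyond the scatter), so the lower numbers seen with the two chains do not carry over to this group. Chloro in place of hydrogen gives a 1.1-fold higher number from compound 1 to compound 4 (0.06 log units; within the scatter), which leaves compound 4 indistinguishable from compound 1 on this read-out and shows that, among these four compounds, filling this position does not by itself lower the number; only the ethyl and butyl chains do so. No measurement at hand accounts for this difference between the chloro group and the two chains.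

Going by these compounds, it remains open whether a longer chain such as hexyl would lower the number further, or whether a branched chain such as tert-butyl would behave like butyl. On these data alone, it is equally open whether another halogen such as bromo, or an oxygen-linked chain such as butoxy, would read like chloro or like the chains.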